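The source may hold more compounds than are shown below. What is called first, only, known or untested is meant among the compounds shown, and "the series" means these compounds.

Of the compounds shown here, three have so far been tested in a functional assay on HCT-116 cells (Homo sapiens) for antiproliferative activity, read by CCK-8 assay, with a stated time of 72 h, tested at 2 uM; a higher number here means a stronger effect of the compound at the concentration tested, a lower number a weaker effect. Compound 1 `CC(C)n1cnc2c(Nc3ccccc3)nc(NCOCc3ccc(C(=O)Nc4ccccc4N)cc3)nc21` gives 6.85%. Compound 2 `Cc1ccc(Nc2nc(Cl)nc3c2ncn3Cc2ccc(C(=O)Nc3ccccc3N)cc2)cc1` gives 76.3%, and compound 3 `Nc1ccccc1NC(=O)c1ccc(Cn2cnc3c(Nc4ccccc4)nc(Cl)nc32)cc1` gives 71.4%. Among these three numbers compound 3 stands second highest; its nearest neighbour is compound 2, and the single change between them, a number 4.9 percentage points lower from compound 2 to compound 3 (within the scatter), lies within the scatter. Compound 1 sits far below both, but it differs from compound 3 in several places at once, so its value can only be set beside the others without tracing the gap to one change.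

Compound 4 `Nc1ccccc1NC(=O)c1ccc(Cn2cnc3c(NCc4ccccc4)nc(Cl)nc32)cc1` is the next to be measured. It differs from compound 3 in one place: benzyl in place of phenyl on a nitrogen on an aromatic ring. Going by the values given here, none of the measured steps touches this nitrogen, so there is no direct precedent in this assay for a change there, and the sole step recorded concerns another part of the molecule. The expectation is therefore cautious: compound 4 is estimated to keep much of the effect of compound 3, with a step of a number 16.4 percentage points lower from compound 3 to compound 4 (beyond the scatter). Compound 4 is expected to give about 55%, within a range from 25% to 80%.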

Compound 4, a percentage reported as inhibition, at one concentration (the size of the read-out at that concentration, not a potency): 68.3%
Estimate against measurement, compound 4: 13.3 percentage points below; measured number inside the range.
By their numbers in this assay, from the lowest: compound 1; then compounds 4, 3 and 2 (each within the scatter of the next).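

Replacing anilino with benzylamino on this nitrogen gives a number 3.1 percentage points lower from compound 3 to compound 4 (within the scatter) in this assay, so adding a carbon between the nitrogen and the ring leaves no difference that can be read here. Benzyl in place of 4-methylphenyl gives a number 8 percentage points lower from compound 2 to compound 4 (within the scatter), which means that compounds 2, 3 and 4, carrying three different groups at this nitrogen, all lie within the scatter of one another. Nothing measured here bears on why these values sit so close together.

The compounds shown leave open whether this level of effect survives a longer chain such as phenethyl, a ring-free group such as a plain ethyl, or a phenyl ring carrying a carboxylic acid or an amine. Since each value comes from a single concentration, whether compounds 2, 3 and 4 would show a stronger or weaker effect than one another at any other concentration also remains unresolved.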